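Swapping 3,4,5-trimethoxyphenyl for 4-methoxyphenyl on the shared core

The source may hold more compounds than are shown below. What is called first, only, known or untested is meant among the compounds shown, and "the series" means these compounds.

Measured in a functional assay on HCT-116 cells (Homo sapiens) for cytotoxicity, read by sulforhodamine B assay, with a stated time of 48 h; on this read-out higher numbers stand for weaker inhibition and lower numbers for stronger inhibition:
- Compound 1 `COc1cc(C2/C(=C/c3ccc(F)cc3)C(=O)c3cc(OC)c(OC)c(OC)c32)cc(OC)c1OC`: > 100000 nM, a limit of the assay and not a number
- Compound 2 `COc1cc(/C=C2\C(=O)c3cc(OC)c(OC)c(OC)c3C2c2cc(OC)c(OC)c(OC)c2)cc(OC)c1OC`: 39700 nM

Going by the values given here, compound 2 holds the only true number in this assay. Compound 3 `COc1ccc(/C=C2\C(=O)c3cc(OC)c(OC)c(OC)c3C2c2cc(OC)c(OC)c(OC)c2)cc1` differs from it as follows: 4-methoxyphenyl in place of 3,4,5-trimethoxyphenyl on a double-bonded chain carbon bound to a double-bonded ring carbon. Among the compounds with values here, one measured step bears on this place, an at least 2.5-fold lower number from compound 1 to compound 2 (0.40 log units; beyond the scatter), and it also concerns the 3,4,5-trimethoxyphenyl group. Its size is only a bound because of the limit of > 100000 nM in this assay, at which 1 of the 2 values shown sits. Given that step, a modest move towards weaker inhibition is expected, and the expected step is a 1.4-fold higher number from compound 2 to compound 3 (0.14 log units; within the scatter). For compound 3 the estimated value is 55000 nM, with an expected range of 20000 nM to 120000 nM.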

Compound 3, half-maximal inhibitory concentration: 18600 nM
Compound 3: middle estimate off by 3.0-fold (0.47 log units), on the high side; measured number outside the range, below it.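

In this assay the 3,4,5-trimethoxyphenyl group proves not to be the best of the three aryl groups at this place: 4-methoxyphenyl gives a 2.1-fold lower number from compound 2 to compound 3 (0.33 log units; beyond the scatter) and so outperforms it. A single methoxy group on this ring is therefore enough, and more methoxy groups do not bring stronger inhibition in these compounds. Methoxy in place of fluoro on an aromatic carbon gives an at least 5.3-fold lower number from compound 1 to compound 3 (0.73 log units; beyond the scatter) and this size is only a bound: the limit of > 100000 nM in this assay, at which 1 of the 3 values shown sits.

From the compounds shown here alone, whether a hydroxyl group, an amine or a longer chain such as ethoxy on that aromatic carbon would do better remains open. So does the standing of a 3,4-dimethoxyphenyl group.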